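From bromo to isopropyl on the benzoyl end

The source may report more compounds than this note shows. Statements on the series, on what has been measured and on what is new or still open speak of the compounds shown alone.

In a functional assay on OCI-Ly3 cells (Homo sapiens) for inhibition, read by CellTiter-Glo, with stated times of 48 h and 96 h (a lower number here means a stronger inhibitor of growth, a higher number a weaker inhibitor of growth), compound 1 `CCC(=O)[C@H](CCCNC(=N)N)NC(=O)[C@@H]1CCCN1C(=O)[C@@H](NC(=O)[C@H](CC(C)C)NC(=O)OCc1ccccc1)C(C)C` gives > 20000 nM and that is a limit of the assay. Compound 2 `CC(C)[C@H](NC(=O)c1cccc(Br)c1)C(=O)N1CCC[C@H]1C(=O)N[C@@H](CCCNC(=N)N)C(=O)CF` gives 530 nM and compound 3 `CC(C)[C@H](NC(=O)c1ccc(Br)cc1)C(=O)N1CCC[C@H]1C(=O)N[C@@H](CCCNC(=N)N)C(=O)CF` gives 130 nM as the lowest number shown. The step of a 4.1-fold lower number from compound 2 to compound 3 (0.61 log units; beyond the scatter) came with 4-bromophenyl in place of 3-bromophenyl on a carbonyl carbon. Compound 4 `CC(C)c1ccc(C(=O)N[C@H](C(=O)N2CCC[C@H]2C(=O)N[C@@H](CCCNC(=N)N)C(=O)CF)C(C)C)cc1` has isopropyl in place of bromo on an aromatic carbon, para to a large group (isopropyl in place of bromo on an aromatic carbon). Among the measured compounds shown here, no measured step replaces the bromo itself, and the step from compound 2 gives only a rough scale, so a small rise in the number is expected. The expected change is a 1.5-fold higher number from compound 3 to compound 4 (0.19 log units; within the scatter) and it may stay inside the scatter. In this assay compound 4 is estimated at 200 nM with a range from 70 nM to 600 nM as expected bounds.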

Compound 4, concentration for 50% growth inhibition: 270 nM
Estimate against measurement, compound 4: 1.4-fold (0.13 log units) below; measured number inside the range.
By their numbers in this assay, from the lowest: compound 3; then compounds 4 and 2 (each within the scatter of the next). At a limit, above all of these: compound 1.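

In this assay the 4-bromophenyl group can be exchanged for 4-isopropylphenyl only at some cost, with a 2.1-fold higher number from compound 3 to compound 4 (0.32 log units; beyond the scatter), so the identity of the group at this position moves the number, and not only its place on the ring. The other new step, a 2.0-fold lower number from compound 2 to compound 4 (0.29 log units; within the scatter), leaves those two compounds unseparated. Nothing given here accounts for the change from bromo to isopropyl.

Still open, going by these compounds, is how an amine, a carboxylic acid or a methoxy group on this same aromatic carbon would compare with compound 3.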